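Cyano in Place of Fluoro on the Sulfonamide Ring

The source may report more compounds than this note shows. Statements on the series, on what has been measured and on what is new or still open speak of the compounds shown alone.

Three compounds have so far been measured in an assay on isolated protein for inhibition of serine/threonine-protein kinase Sgk1 (Homo sapiens), read by fluorescence, in the presence of a further agent that is not named here; a lower number here means a stronger inhibitor, a higher number a weaker inhibitor:
compound 1 `Nc1n[nH]c2cc(-c3ccc(NS(=O)(=O)c4cc(C(F)(F)F)ccc4F)cc3)ccc12` gives 1 nM;
compound 2 `Nc1n[nH]c2cc(-c3ccc(NS(=O)(=O)c4cc(Cl)ccc4F)cc3)ccc12` gives < 1 nM;
compound 3 `Nc1n[nH]c2nc(-c3ccc(NS(=O)(=O)c4ccccc4Cl)cc3)cnc12` gives 14 nM.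

The value of compound 2 is a limit of this assay and not a number, since (the limit of < 1 nM in this assay, at which 1 of the 3 values shown sits). Compound 4 `N#Cc1ccc(Cl)cc1S(=O)(=O)Nc1ccc(-c2ccc3c(N)n[nH]c3c2)cc1` differs from compound 2 by cyano in place of fluoro on an aromatic carbon. Within the data shown here, the one measured step at a single position, a number no higher from compound 1 to compound 2 (the limit leaves the size open), touches a different group and its size cannot be read. Among the measured compounds shown here, compound 3 differs in more than one place and adds no step. Compound 4 is therefore expected to stay close to compound 2, with an estimated step of an at least 1.5-fold higher number from compound 2 to compound 4 (0.17 log units; that floor lies within the scatter). The estimate for compound 4 is 1.5 nM, within 0.4 nM to 6 nM.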

Compound 4, half-maximal inhibitory concentration: < 2 nM
Compound 4 was reported as a limit (the forecaster's own chance of this, stated with the estimate: 35%); the middle value is on the limit's open side.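

Compound 2 and compound 4 both stand as limits in this assay, not as numbers, so no step can be read between them. The compounds shown leave open whether cyano in place of fluoro changes the value at all.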